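Replacing 4-chlorophenyl with quinolin-2-yl on compound 3

The source may hold more compounds than are shown below. What is called first, only, known or untested is meant among the compounds shown, and "the series" means these compounds.

In a functional assay on MCF7 cells (Homo sapiens) for antiproliferative activity, read by MTT assay, with a stated time of 72 h (on this read-out higher numbers stand for weaker inhibition and lower numbers for stronger inhibition), compound 1 `CCN1CCN(c2cc(C)c3cc(NC(=O)c4cccc(Cl)c4)ccc3n2)CC1` gives 3820 nM and compound 2 `CCN1CCN(c2cc(C)c3cc(NC(=O)c4ccc(Br)cc4)ccc3n2)CC1` gives 5940 nM while compound 3 `CCN1CCN(c2cc(C)c3cc(NC(=O)c4ccc(Cl)cc4)ccc3n2)CC1` gives 1530 nM as the lowest number of the three. Compound 3 therefore stands as the most potent of this small set. Both steps leading to it are modest yet beyond the scatter: a 2.5-fold lower number from compound 1 to compound 3 (0.40 log units; beyond the scatter) and a 3.9-fold lower number from compound 2 to compound 3 (0.59 log units; beyond the scatter) on the same read-out. The remaining step, a 1.6-fold higher number from compound 1 to compound 2 (0.19 log units; within the scatter) stays within the scatter.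

Compound 4 `CCN1CCN(c2cc(C)c3cc(NC(=O)c4ccc5ccccc5n4)ccc3n2)CC1` keeps the shared core and carries one change: quinolin-2-yl in place of 4-chlorophenyl on a carbonyl carbon with quinolin-2-yl in place of 4-chlorophenyl on a carbonyl carbon. Within the data shown here, no measured step brings in a ring with a hetero atom, so none of them predicts this swap directly. Among the measured compounds shown here, they show only that changing the group on the carbonyl carbon has so far moved the number modestly. Compound 3 already holds the lowest number at 1530 nM and both other groups gave higher numbers, so a modest rise is the likelier outcome. The expected step is a 2.0-fold higher number from compound 3 to compound 4 (0.29 log units; within the scatter) in this assay and it remains uncertain. For compound 4 the estimated value is 3000 nM with an expected range from 1000 nM to 9000 nM in this cell test.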

Compound 4, half-maximal inhibitory concentration: 7060 nM
Estimate against measurement, compound 4: 2.4-fold (0.37 log units) below, and the stated range covers the measured number.
By their numbers in this assay, from the lowest: compound 3; then compounds 1, 2 and 4 (each within the scatter of the next).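

In this assay this is the first group on the carbonyl carbon to bring in a ring with a hetero atom and a second aromatic ring, and it does not hold the number of 4-chlorophenyl: the result is a 4.6-fold higher number from compound 3 to compound 4 (0.66 log units; beyond the scatter), so compound 3 is now separated from every other compound shown by a step beyond the scatter. Quinolin-2-yl cannot be told apart from the two other halogen-bearing groups, with a 1.2-fold higher number from compound 2 to compound 4 (0.08 log units; within the scatter) and a 1.8-fold higher number from compound 1 to compound 4 (0.27 log units; within the scatter), so the amides in compounds 1, 2 and 4 form one band despite their different rings, and only 4-chlorophenyl stands out at this position. Nothing available here explains the higher number of compound 4 or connects it to the hydrogen-bond acceptor that quinolin-2-yl adds.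

Compound 4 changes two things at once, the added ring and the ring nitrogen, so the compounds shown cannot say which of them goes with the change in number, and a single aromatic ring with one hetero atom would be needed to pull them apart. Also open, as far as these compounds go, is how an amine, a methoxy group or a carboxylic acid would compare with chloro on the phenyl ring.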